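Catechol ether amides: pyridin-4-yl amide, estimate before measurement

The compounds below may be only part of what the source reports. "The series", "measured", "known", "first", "only" and "open" are said of these compounds alone.

Measured so far in an assay on isolated protein for inhibition of phosphodiesterase 4A (Sus scrofa); on this read-out higher numbers stand for weaker inhibition and lower numbers for stronger inhibition:
- compound 1, `COc1ccc(C(=O)Nc2ccccc2F)cc1OC1CCCC1`: 10700 nM
- compound 2, `COc1ccc(C(=O)Nc2c(F)cccc2Cl)cc1OC1CCCC1`: 240 nM
- compound 3, `COc1ccc(C(=O)Nc2ccccc2O)cc1OC1CCCC1`: 1300 nM

Compound 3 stands second highest of the three numbers; compound 2 sits at a 5.4-fold higher number from compound 2 to compound 3 (0.73 log units; beyond the scatter) and compound 1 at an 8.2-fold lower number from compound 1 to compound 3 (0.92 log units; beyond the scatter). Compound 4, `COc1ccc(C(=O)Nc2ccncc2)cc1OC1CCCC1`, is not yet measured; its change is pyridin-4-yl in place of 2-hydroxyphenyl on an amide-type nitrogen. Among the compounds with values here, no measured step bears on this change directly. The ring on the amide nitrogen is clearly sensitive: a 45-fold lower number from compound 1 to compound 2 (1.65 log units; beyond the scatter) and an 8.2-fold lower number from compound 1 to compound 3 (0.92 log units; beyond the scatter), both beyond the scatter, with the plainest ring of the three, in compound 1, giving the highest number. With both the hydroxy and any halogen gone, a higher number than compound 3 is expected for compound 4 in this assay, a 3.8-fold higher number from compound 3 to compound 4 (0.59 log units; beyond the scatter), but with wide uncertainty. Estimated value for compound 4: 5000 nM, range 1000 nM to 25000 nM.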

Compound 4, half-maximal inhibitory concentration: 800 nM
For compound 4 the middle estimate is 6.3-fold (0.80 log units) above the measured one; the whole stated range lies above it.
By their numbers in this assay, from the lowest: compound 2; then compounds 4 and 3 (each within the scatter of the next); then compound 1.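

In this assay, pyridin-4-yl on the amide-type nitrogen stands level with 2-hydroxyphenyl (a 1.6-fold lower number from compound 3 to compound 4 (0.21 log units; within the scatter)), so the hydrogen-bond donor of 2-hydroxyphenyl is not needed to reach this range. The ring also needs neither hydroxy nor halogen to differ clearly from 2-fluorophenyl (a 13-fold lower number from compound 1 to compound 4 (1.13 log units; beyond the scatter)), although 2-chloro-6-fluorophenyl keeps the lowest number (a 3.3-fold higher number from compound 2 to compound 4 (0.52 log units; beyond the scatter)). Nothing available explains these differences.

Open, going by these compounds, is whether chloro on the pyridin-4-yl ring would lower the number further. The effect of pyridin-3-yl in its place is also unknown.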